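From Compound 1 to Compound 3: An Expectation Before Measurement

The source may report more compounds than this note shows. Statements on the series, on what has been measured and on what is new or still open speak of the compounds shown alone.

Compound 1 `Cc1cc(-c2ccc3[nH]c(=O)nc(-c4ccccc4)c3c2)ccn1` was tested in an ADME assay on L6 cells (Rattus norvegicus) for cytotoxicity, read by fluorescence and resazurin assay, with a stated time of 72 h; on this read-out higher numbers stand for an effect only at larger amounts of compound and lower numbers for an effect already at smaller amounts. In this assay compound 1 gives > 50000 nM, which is a limit of the assay rather than a number. Compound 2 `O=c1nc(-c2ccccc2)c2cc(-c3ccccc3)ccc2[nH]1` gives > 50000 nM in this assay, again a limit. Among the measured compounds shown here, the step that the two limits leave unreadable from compound 1 to compound 2 therefore cannot be read, and the limit of > 50000 nM in this assay, at which 2 of the 2 values shown sit, is the only evidence at hand. Compound 3 `Cn1cc(-c2ccc3[nH]c(=O)nc(-c4ccccc4)c3c2)cn1` differs from compound 1 by 1-methyl-1H-pyrazol-4-yl in place of 2-methylpyridin-4-yl on an aromatic carbon. For the measured compounds named here, no measured step bears on this change, so compound 3 is expected to show no shift beyond the scatter in this assay, that is a step that the limit leaves unreadable from compound 1 to compound 3. Compound 3 is expected at 80000 nM, between 30000 nM and 200000 nM.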

Compound 3, half-maximal effective concentration: > 50000 nM
Compound 3: only a limit was reported (the forecaster's own chance of this, stated with the estimate: 85%); the middle value lies beyond the limit too.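

In this assay no step among compound 1, compound 2 and compound 3 can be read, as all three stand at a limit: the limit of > 50000 nM in this assay, at which 3 of the 3 values shown sit.

In this assay the compounds shown leave open at what amount, if any, compound 1, compound 2 or compound 3 would show an effect.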